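This account rests on a few compounds, and the source may have more. Where it says the series, first, only, none or still open, it means among the compounds named here.

Compound 3 `N=C(N)c1cccc(CN2CC[C@H](NS(=O)(=O)c3ccc(-c4ccncc4)s3)C2=O)c1` is known in an assay on isolated protein for inhibition of Trypsin II (Bos taurus) (on this read-out lower numbers stand for stronger inhibition and higher numbers for weaker inhibition), only as a limit; in this assay compound 3 gives > 2900 nM. Compound 1 `N=C(N)c1cccc(CN2CC[C@H](NS(=O)(=O)c3ccc(-c4ccccn4)cc3)C2=O)c1` likewise reaches only a limit, and compound 1 gives > 2900 nM. Compound 2 `N=C(N)c1cccc(CN2CC[C@H](NS(=O)(=O)c3ccc(-c4cc[n+]([O-])cc4)cc3)C2=O)c1` also stops at a limit, and compound 2 gives > 2900 nM. The step that the two limits leave unreadable from compound 1 to compound 2 therefore cannot be read, since every value sits at the limit of > 2900 nM in this assay, at which 3 of the 3 values shown sit. Compound 4 `N=C(N)c1cccc(CN2CC[C@H](NS(=O)(=O)c3ccc(-c4ccon4)s3)C2=O)c1` differs from compound 3 by 1,2-oxazol-3-yl in place of pyridin-4-yl on an aromatic carbon. Within the data shown here, no measured step bears on this change, and the unreadable step gives no direction. The step that the limit leaves unreadable from compound 3 to compound 4 is accordingly expected to be small, with another limit the most likely outcome. Compound 4 is estimated at 6000 nM, within a range from 2000 nM to 30000 nM.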

Compound 4, inhibition constant: 1900 nM
Beside the measured number, compound 4's estimate is 3.2-fold (0.50 log units) above it; measured number below the stated range.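

In this assay, compound 4 is the only compound shown that gives a number rather than a limit, so a group next to the ring sulfur can yield a readable value: the limit of > 2900 nM in this assay, at which 3 of the 4 values shown sit. Putting 1,2-oxazol-3-yl in place of pyridin-4-yl gives an at least 1.5-fold lower number from compound 3 to compound 4 (0.18 log units; that floor lies within the scatter). Only this floor is known, so the step may be larger or may be no real change.

From the compounds shown here alone, the true size of the step remains open. So does whether an amine or a carboxylic acid at this place would give a readable value.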